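The source may hold more compounds than are shown below. What is called first, only, known or untested is meant among the compounds shown, and "the series" means these compounds.

Compound 1 `Cn1nc(-c2nnc(S)o2)cc1-c1ccc(C(F)(F)F)cc1` and compound 2 `Cn1nc(-c2ccc(C(F)(F)F)cc2)cc1-c1nnc(SCc2c(F)cccc2F)o1` share the same core and differ only at the sulfur-bearing end. In a functional assay on MCF7 cells (Homo sapiens) for cytotoxicity, read by MTT assay, with a stated time of 24 h (a lower number here means a stronger inhibitor, a higher number a weaker inhibitor), compound 1 reaches only the limit > 100000 nM, which is a limit of the assay and not a number. In this assay, going by the values given here, compound 2 gives 46200 nM, the only true number among the values shown. The remaining value shown is the limit of > 100000 nM in this assay, at which 1 of the 2 values shown sits. Compound 3 `Cn1nc(-c2ccc(C(F)(F)F)cc2)cc1-c1nnc(SCc2cccc(Cl)c2Cl)o1` has not yet been measured. It differs from compound 2 by one change: 2,3-dichlorophenyl in place of 2,6-difluorophenyl on a saturated chain carbon bound to a sulfur. Among the compounds with values here, no measured pair shows what such an exchange does, so no step beyond the usual scatter is expected in either direction. The step from compound 2 to compound 3 is therefore expected to be a 1.2-fold lower number from compound 2 to compound 3 (0.06 log units; within the scatter). For compound 3 in this assay the estimate is 40000 nM, with a likely range from 14000 nM to 100000 nM.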

Compound 3, half-maximal inhibitory concentration: 60200 nM
Estimate against measurement, compound 3: 1.5-fold (0.18 log units) below; low and high end bracket the measured number.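

In this assay, putting 2,3-dichlorophenyl in place of 2,6-difluorophenyl on a saturated chain carbon bound to a sulfur gives a 1.3-fold higher number from compound 2 to compound 3 (0.11 log units; within the scatter), so the two groups cannot be told apart here. Going by these compounds alone, this is the first measured pair at this position, and it shows that a change of both the halogen and its places on the ring can leave the number within the usual scatter. Compound 1 remains a limit of the assay and not a number: the limit of > 100000 nM in this assay, at which 1 of the 3 values shown sits.

This single pair changes the halogen and its places together, so the contribution of each cannot be read separately. On these data alone, it also remains open whether an unsubstituted phenyl ring, a ring carrying an amine or a carboxylic acid, or a longer chain between the sulfur and the ring would give a step beyond the scatter.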